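Sulfonamide chain extension: estimate for compound 4

The source may hold more compounds than are shown below. What is called first, only, known or untested is meant among the compounds shown, and "the series" means these compounds.

Measured so far in a functional assay for antagonist activity at transient receptor potential cation channel subfamily V member 1 (Rattus norvegicus); a higher number here means a weaker inhibitor, a lower number a stronger inhibitor:
compound 1 `Cc1cccnc1-c1ccc(C(=O)Nc2ccc(C(C)(C)C)cc2)cc1` gives 9 nM
compound 2 `CCCOc1cccnc1-c1ccc(C(=O)Nc2ccc(C(C)(C)C)cc2)cc1` gives 20 nM
compound 3 `CC(C)(C)c1ccc(NC(=O)c2ccc(-c3ncccc3NS(C)(=O)=O)cc2)cc1` gives 35 nM

Compound 3 carries the highest of the three numbers, though it lies within the scatter of compound 2 (a 1.8-fold higher number from compound 2 to compound 3 (0.24 log units; within the scatter)) and separates only from compound 1 (a 3.9-fold higher number from compound 1 to compound 3 (0.59 log units; beyond the scatter)). Compound 4 `CCS(=O)(=O)Nc1cccnc1-c1ccc(C(=O)Nc2ccc(C(C)(C)C)cc2)cc1` differs from compound 3 by methyl in place of hydrogen on a saturated chain carbon bound to a sulfonyl sulfur. Going by the values given here, no measured step touches that place: a 2.2-fold higher number from compound 1 to compound 2 (0.35 log units; beyond the scatter) and a 3.9-fold higher number from compound 1 to compound 3 (0.59 log units; beyond the scatter) both exchange groups on an aromatic carbon, and the shared core is otherwise unchanged. With nothing bearing on a chain homologation at the sulfonyl, the expectation for this assay is a step no larger than the scatter, with no direction favoured. Compound 4 is estimated at 35 nM, range 15 nM to 80 nM, an expected step of no change at the digits printed from compound 3 to compound 4 (within the scatter).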

Compound 4, half-maximal inhibitory concentration: 4 nM
Compound 4: middle estimate off by 8.8-fold (0.94 log units), on the high side; measured number outside the range, below it.
By their numbers in this assay, from the lowest: compound 4; then compound 1; then compounds 2 and 3 (each within the scatter of the next).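

In this assay, the sulfonyl chain carbon proves sensitive to one added methyl (  an 8.8-fold lower number from compound 3 to compound 4 (0.94 log units; beyond the scatter)), so methanesulfonamido and (ethylsulfonyl)amino are not interchangeable on this core. The (ethylsulfonyl)amino group also gives a lower number than propoxy (a 5.0-fold lower number from compound 2 to compound 4 (0.70 log units; beyond the scatter)) and methyl (a 2.3-fold lower number from compound 1 to compound 4 (0.35 log units; beyond the scatter)), whereas methanesulfonamido gave no such advantage over either. No supporting evidence bears on this result.

The compounds shown leave open whether a propyl or isopropyl chain on the sulfonyl continues the change from methyl to ethyl or reverses it. A cyclopropyl group there is equally unresolved.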